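The source may hold more compounds than are shown below. What is called first, only, known or untested is meant among the compounds shown, and "the series" means these compounds.

Measured compounds:
compound 1, `N[C@H]1CC[C@H](Nc2ccc3ncc(-c4cnc(Nc5ncccc5F)nc4)n3n2)CC1`, in a physicochemical assay for lipophilicity (a higher number here means a more lipophilic compound, a lower number a more polar compound), compound 1 gives 0.2
compound 2, `Cc1ccc2ncc(-c3cnc(Nc4ncccc4F)nc3)n2n1`, in this assay compound 2 gives 2.5

Compound 2 stands highest of the two numbers in this assay; its nearest neighbour is compound 1, a number lower beyond the scatter. Compound 3, `Fc1cccnc1Nc1ncc(-c2cnc3ccc(N4CCNCC4)nn23)cn1`, has not yet been measured in this assay. It differs from compound 2 by piperazin-1-yl in place of methyl on an aromatic carbon.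

Among the measured compounds shown here, one measured step bears on this change. Going from an amine-bearing substituent to a methyl, a number 2.30 log units higher from compound 1 to compound 2 (beyond the scatter), a large rise. Compound 3 goes the other way, replacing the methyl with a ring that carries one hydrogen-bond donor and two hydrogen-bond acceptors, so a drop beyond the scatter is expected, likely somewhat smaller than the step to compound 2 because a number 2.30 log units higher from compound 1 to compound 2 (beyond the scatter) removed a group with more polar atoms. Compound 3 is therefore estimated at 0.7, range 0 to 1.5, an expected step of a number 1.80 log units lower from compound 2 to compound 3 (beyond the scatter).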

Compound 3, distribution coefficient: 0.7
The estimate for compound 3 equals the measured number at the digits printed, and the stated range covers the measured number.
By their numbers in this assay, from the lowest: compound 1; then compound 3; then compound 2.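

In this assay piperazin-1-yl in place of methyl gives a number 1.80 log units lower from compound 2 to compound 3 (beyond the scatter) at this aromatic carbon, so a second amine-bearing group also sits far from methyl and the large shift is not tied to the (4-aminocyclohexyl)amino group alone. The two amine-bearing groups can also be told apart, since piperazin-1-yl in place of (4-aminocyclohexyl)amino gives a number 0.50 log units higher from compound 1 to compound 3 (beyond the scatter) on the same core, a modest step beside the large one from methyl. Nothing shown here accounts for the size of either step.

Where morpholin-4-yl or 4-methylpiperazin-1-yl would fall at this carbon relative to piperazin-1-yl and methyl remains open. So does the reading in this assay for a carboxylic acid or a longer chain ending in an amine at the same place.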